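A Bromine Added to a Compound at the Limit

This account rests on a few compounds, and the source may have more. Where it says the series, first, only, none or still open, it means among the compounds named here.

Among the compounds with values here, compound 1, `Cc1ccnc(OCc2ccc(F)cc2)c1C(=O)NC1CCCCCC1`, is one of two compounds measured so far in an assay on HEK293 cells for inhibition of Lysophosphatidylserine lipase ABHD12 (Homo sapiens), with stated times of 30 min and 5 min; a higher number here means a weaker inhibitor, a lower number a stronger inhibitor. In this assay compound 1 gives > 10000 nM, which is a limit of the assay rather than a number. The other compound, compound 2, `O=C(NC1CCCCCC1)c1c(-c2ccccc2)ccn(Cc2ccc(F)cc2)c1=O`, is measured in this assay as well, and compound 2 gives > 10000 nM, again a limit. Both values thus sit at the same place, as the limit of > 10000 nM in this assay, at which 2 of the 2 values shown sit, shows, so compound 1 stands together with compound 2 at the edge of what this assay can report, and nothing separates the two. Within the data shown here, no step between two measured compounds has been recorded, so there is no measured change to compare against. Compound 3, `Cc1c(Br)cnc(OCc2ccc(F)cc2)c1C(=O)NC1CCCCCC1`, is not yet measured. It differs from compound 1 by bromo in place of hydrogen on an aromatic carbon. With both measured compounds at a limit, no direction can be read from the data. The expected step of a number no higher from compound 1 to compound 3 (the limit leaves the size open) is accordingly none beyond the usual scatter. Compound 3 is therefore estimated to give 10000 nM in this assay, within a range from 2000 nM to 50000 nM.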

Compound 3, half-maximal inhibitory concentration: > 10000 nM
Compound 3: no number, only a limit; the forecaster's own chance of this, stated with the estimate: 75%; the middle value sits exactly at the limit.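

In this assay compound 3 gives > 10000 nM and this is a limit of the assay, not a number. Within the data shown here, compound 1 and compound 3 stand at the same limit, so no step between them can be read: the limit of > 10000 nM in this assay, at which 3 of the 3 values shown sit. The compounds shown leave open whether bromo in place of hydrogen on an aromatic carbon changes inhibition at all, and how strongly any of them inhibits the enzyme.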